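A few compounds are considered here, and "the series" means these few. Any claim that something is new, unique, unknown or untested is made for them only; others in the source may bear on it.

Two members of one series set the scale. Compound 1 `COc1ccc(/C=C\C(=O)O)c(OCc2cn(-c3ccc(NC(=O)c4ccccc4)cc3)nn2)c1CC=C(C)C` gives 42700 nM in a functional assay on A549 cells (Homo sapiens) for cytotoxicity, read by MTT assay, with a stated time of 24 h (on this read-out higher numbers stand for weaker inhibition and lower numbers for stronger inhibition), and compound 2 `COc1cccc(-n2cc(COc3c(/C=C\C(=O)O)ccc(OC)c3CC=C(C)C)nn2)c1` gives 42700 nM in this assay; these two values lie within the usual scatter of each other. Compound 3 `COc1ccc(/C=C\C(=O)O)c(OCc2cn(-c3ccc(CO)cc3)nn2)c1CC=C(C)C` is recorded as "not determined" (no result reported) in this assay, so it has no place on this scale. Compound 4 `COc1ccc(/C=C\C(=O)O)c(OCc2cn(-c3ccccc3C#N)nn2)c1CC=C(C)C` differs from compound 3 by 2-cyanophenyl in place of 4-(hydroxymethyl)phenyl on an aromatic nitrogen. Going by the values given here, no comparison between measured compounds shows how large a step such a change brings in this assay, in which direction, or whether it rises above the scatter at all; the only guide is that compounds 1 and 2 sit close together. Compound 4 is expected to give about 40000 nM in this assay, with a likely range from 15000 nM to 100000 nM.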

Compound 4, half-maximal inhibitory concentration: 38600 nM
Beside the measured number, compound 4's estimate is 1.0-fold (0.02 log units) above it, within the range that was stated.
By their numbers in this assay, from the lowest: compounds 4, 1 and 2 (each within the scatter of the next).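

In this assay, going by these compounds alone, 2-cyanophenyl in place of 3-methoxyphenyl on an aromatic nitrogen gives a 1.1-fold lower number from compound 2 to compound 4 (0.04 log units; within the scatter), the first comparison at this position. Here, exchanging one substituted phenyl group for the other, with a different group at a different ring position, leaves the number within the scatter. No supporting measurement explains this result.

The step from compound 3 to compound 4 cannot be read, as compound 3 has no value. Going by these compounds, whether an amine, a carboxylic acid or a longer alkyl chain at this position would shift the number remains open.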